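Methoxy in Place of Fluoro: What to Expect for Compound 4

The compounds below may be only part of what the source reports. "The series", "measured", "known", "first", "only" and "open" are said of these compounds alone.

Compound 1 `Cc1ccc(Cn2c(/C=C3\SC(=S)N(CC(=O)O)C3=O)nc3ccc(F)cc32)cc1`: 5820 nM
Compound 2 `COc1ccc2nc(/C=C3\SC(=S)N(CC(=O)O)C3=O)n(Cc3ccc(C)cc3)c2c1`: 16200 nM
Compound 3 `O=C(O)CN1C(=O)/C(=C/c2nc3cc(F)ccc3n2Cc2ccccc2F)SC1=S`: a limit of the assay, > 50000 nM

All three were tested in a functional assay on PC-3 cells (Homo sapiens) for cytotoxicity, read by MTT assay, with a stated time of 48 h; a higher number here means a weaker inhibitor, a lower number a stronger inhibitor. Compound 2 differs from compound 1 by one change, (methoxy in place of fluoro on an aromatic carbon), and that change gave a 2.8-fold higher number from compound 1 to compound 2 (0.44 log units; beyond the scatter). The difference between the core of compound 1 and the core of compound 3 is not broken down here. Compound 4 `COc1ccc2c(c1)nc(/C=C1\SC(=S)N(CC(=O)O)C1=O)n2Cc1ccccc1F`, not yet measured, carries the same change relative to compound 3: methoxy in place of fluoro on an aromatic carbon. For compound 3 the assay reports only a limit, > 50000 nM. Compound 3 already stands at the limit of > 50000 nM in this assay, at which 1 of the 3 values shown sits, and the measured change moved the number upward; compound 4 is therefore expected to stay beyond that limit, with an expected step that the limit leaves unreadable from compound 3 to compound 4. Compound 4 is estimated at 90000 nM, between 40000 nM and 250000 nM.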

Compound 4, half-maximal inhibitory concentration: 24700 nM
Compound 4: the middle estimate sits 3.6-fold (0.56 log units) above what was measured; measured number outside the range, below it.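

In this assay, methoxy in place of fluoro on an aromatic carbon gave an at least 2.0-fold lower number from compound 3 to compound 4 (0.30 log units; that floor lies within the scatter). The change therefore did not carry over from one core to the other as a single fixed step, although two pairs set no rule for other cores and give no reason for the difference: the same change on two cores in this assay, a 2.8-fold higher number (0.44 log units; beyond the scatter) from compound 1 to compound 2 and an at least 2.0-fold lower number (0.30 log units; that floor lies within the scatter) from compound 3 to compound 4, at least 5.6-fold (0.75 log units) apart, beyond the scatter of two such steps. The value of compound 3 is a limit of the assay, > 50000 nM.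

The compounds shown leave open how an amine or a chloro group on that same aromatic carbon would read on either core. They also leave open whether a third core would follow the step seen on the core of compound 1 or the one seen on the core of compound 3.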